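A few compounds are considered here, and "the series" means these few. Any claim that something is new, unique, unknown or untested is made for them only; others in the source may bear on it.

Among the measured compounds shown here, in a functional assay on L5178Y cells (Mus musculus) for cytotoxicity, read by MTT assay (on this read-out higher numbers stand for weaker inhibition and lower numbers for stronger inhibition), compound 3 `CC(C)(C)c1ccc(OCCCCN2CCN(c3ncccn3)CC2)cc1` gives 20.8 nM, the lowest of the numbers measured so far. Compound 1 `CCC(=O)c1ccc(OCCCN2CCN(c3cnccn3)CC2)cc1` gives 47.5 nM, a higher number. Compound 2 `CC(=O)c1ccc(OCCCCN2CCN(c3ncccn3)CC2)cc1` gives > 100 nM, which is a limit of the assay and not a number. Compound 2 and compound 3 differ in one place, with tert-butyl in place of acetyl on an aromatic carbon, and that change gave an at least 4.8-fold lower number from compound 2 to compound 3 (0.68 log units; beyond the scatter).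

Compound 4 `CC(C)(C)c1ccc(OCCCCN2CCN(c3cnccn3)CC2)cc1` has the same atoms as compound 3, joined differently: pyrazin-2-yl in place of pyrimidin-2-yl on an amine nitrogen in a ring. This puts pyrazin-2-yl in place of pyrimidin-2-yl on an amine nitrogen in a ring. For the measured compounds named here, the one measured step lies elsewhere in the molecule, so no measured step tests this swap directly. The nearest hint is compound 1, which carries pyrazin-2-yl and still gives a real number, 47.5 nM, although it also differs from compound 3 in other places. A small change therefore seems the most reasonable expectation, with a slight lean towards a higher number in this assay. The expected size is a 1.3-fold higher number from compound 3 to compound 4 (0.10 log units; within the scatter), which would not stand beyond the scatter. For compound 4 the estimated value is 26 nM, with an expected range from 11 nM to 60 nM.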

Compound 4, half-maximal inhibitory concentration: 18.3 nM
Compound 4: middle estimate off by 1.4-fold (0.15 log units), on the high side; the range from low to high includes it.
By their numbers in this assay, from the lowest: compounds 4 and 3 (each within the scatter of the next); then compound 1. At a limit, above all of these: compound 2.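

Compound 3 and compound 4 give the first direct test of pyrazin-2-yl in place of pyrimidin-2-yl on an amine nitrogen in a ring. In this assay this swap gives a 1.1-fold lower number from compound 3 to compound 4 (0.06 log units; within the scatter), so on this read-out the two compounds cannot be told apart, and moving a ring nitrogen within this group makes no measurable difference when the rest of the molecule is held fixed. The one clear step shown so far lies at the other end of the molecule, an at least 4.8-fold lower number from compound 2 to compound 3 (0.68 log units; beyond the scatter), which leaves the aromatic carbon bearing tert-butyl, not the group on the amine nitrogen, as the place where a change has registered beyond the scatter, and nothing measured here says why this swap leaves the read-out unmoved.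

From the compounds shown here alone, it remains open whether the two groups would also match with acetyl in place of tert-butyl, since this swap has been read only with tert-butyl present. A pyridin-2-yl or a plain phenyl ring on the same amine nitrogen, or a longer chain, could still show how much this end of the molecule tolerates.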